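A Nitro Group Added to Two Related Cores

This account rests on a few compounds, and the source may have more. Where it says the series, first, only, none or still open, it means among the compounds named here.

Compound 1 `CN(/N=N/c1ccccc1)c1ccccc1` and compound 3 `CN(/N=N/c1cccc([N+](=O)[O-])c1)c1ccccc1` differ by nitro in place of hydrogen on an aromatic carbon. In an ADME assay on BHK-21 cells (Mesocricetus auratus) for cytotoxicity, read by MTT assay, with a stated time of 96 h (on this read-out higher numbers stand for lower toxicity in this test and lower numbers for higher toxicity in this test), compound 1 reaches only the limit of > 100000 nM. Compound 3 likewise reaches only the limit of > 100000 nM. The step that the two limits leave unreadable from compound 1 to compound 3 therefore cannot be read, since (the limit of > 100000 nM in this assay, at which 2 of the 3 values shown sit). Compound 2 `CN(C)CCCNc1ccc(/N=N/c2ccccc2)cc1` rests on a different core; how that core differs from the core of compound 1 is not broken down here. In this assay, within the data shown here, compound 2 gives 31000 nM, the only number among the three values shown. Compound 4 `CN(C)CCCNc1ccc(/N=N/c2ccc([N+](=O)[O-])cc2)cc1` differs from compound 2 by nitro in place of hydrogen on an aromatic carbon. This is the same kind of change as that from compound 1 to compound 3, though there the nitro group sits meta to a large group and here para to a large group. Because a step that the two limits leave unreadable from compound 1 to compound 3 gives no readable size, the step is expected to be a 1.0-fold lower number from compound 2 to compound 4 (0.01 log units; within the scatter). Compound 4 is expected to give 30000 nM in this assay.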

Compound 4, half-maximal cytotoxic concentration: > 100000 nM
Compound 4: only a limit was reported (the forecaster's own chance of this, stated with the estimate: 25%); middle value at least 3.3-fold (0.52 log units) away from the limit.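

In this assay the nitro group in place of hydrogen gives an at least 3.2-fold higher number from compound 2 to compound 4 (0.50 log units; beyond the scatter) on the core of compound 2, a step beyond the scatter, while the matching step on the core of compound 1 cannot be read. Compound 4 gives > 100000 nM, which is a limit and not a number, so the full size of its step is not shown. Whether the change has the same size on both cores cannot be told, because the values end at a limit: the limit of > 100000 nM in this assay, at which 3 of the 4 values shown sit.

The compounds shown leave open whether the step on the core of compound 2 depends on where the nitro group sits on the ring. They also leave open whether an amine or a carboxylic acid at that place would give a step in the same direction.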